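A few compounds are considered here, and "the series" means these few. Any claim that something is new, unique, unknown or untested is made for them only; others in the source may bear on it.

Working notes on the series. The shared core is seen in compound 1 `c1cnc2c(c1)CCC[C@@H]2N(CC1CC1)C[C@H]1Cc2c(cccc2N2CCNCC2)CN1`, compound 2 `CN(C[C@H]1Cc2c(cccc2N2CCN(C3COC3)CC2)CN1)[C@H]1CCCc2cccnc21` and compound 3 `CN(C[C@@H]1Cc2c(cccc2N2CCNCC2)CN1)[C@H]1CCCc2cccnc21`. In an ADME assay on microsomes from liver (Homo sapiens) for metabolic stability, read by LC-MS, with a stated time of 10 min (on this read-out higher numbers stand for a more stable compound and lower numbers for a less stable compound), compound 1 gives 82.1%, compound 2 gives 83.1% and compound 3 gives 94.2%. Compound 2 stands second highest of the three numbers: compound 1 lies within the scatter of it, while compound 3 lies beyond the scatter, higher. Compound 4 `CN(C[C@H]1Cc2c(cccc2N2C[C@H]3C[C@@H]2CN3)CN1)[C@H]1CCCc2cccnc21` is not yet measured in this assay. It differs from compound 2 in one place: a group of 7 heavy atoms (5 carbon, 2 nitrogen; 2 five-membered non-aromatic rings with 1 hetero atom each) in place of a group of 10 heavy atoms (7 carbon, 2 nitrogen, 1 oxygen; one four-membered non-aromatic ring with 1 hetero atom, one six-membered non-aromatic ring with 2 hetero atoms), on an aromatic carbon. Going by the values given here, no step between measured compounds isolates this change. The step expected in this assay is a number 3.9 percentage points higher from compound 2 to compound 4 (within the scatter), which stays within the scatter. The estimate for compound 4 is 87%, with a range from 75% to 96%.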

Compound 4, percent of the compound remaining: 100%
The estimate for compound 4 lay 13 percentage points below the measured number, outside the stated range (above it).
By their numbers in this assay, from the lowest: compounds 1 and 2 (each within the scatter of the next); then compounds 3 and 4 (each within the scatter of the next).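

At the aromatic carbon of the six-membered aromatic ring of carbon only, putting the group with 2 five-membered non-aromatic rings in place of 4-(oxetan-3-yl)piperazin-1-yl gives, in this assay, a number 16.9 percentage points higher from compound 2 to compound 4 (beyond the scatter), so this position can move the read-out beyond the scatter. Going by these compounds alone, this is the first readable step at this position, and as a single pair it sets no pattern. No available measurement bears on the reason for this step. Still open, as far as these compounds go, is whether the oxetan-3-yl part or the piperazine ring accounts for the step. From the compounds shown here alone, how a morpholine at this aromatic carbon would read also remains open.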